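Thiol ether chain length and inhibition in a tricyclic series

The source may report more compounds than this note shows. Statements on the series, on what has been measured and on what is new or still open speak of the compounds shown alone.

Measured so far:
compound 1, `CCSC1=N[C@@H](C(=O)OC)[C@@H]2C(=O)N(c3ccccc3)C(=O)[C@H]12`, 91% in a functional assay for inhibition, tested at 100 uM; on this read-out lower numbers stand for less inhibition and higher numbers for more inhibition at the one concentration tested (going by the name of the read-out)
compound 2, `CCCSC1=N[C@@H](C(=O)OC)[C@@H]2C(=O)N(c3ccccc3)C(=O)[C@H]12`, 86%
compound 3, `COC(=O)[C@@H]1N=C(SCc2ccccc2)[C@H]2C(=O)N(c3ccccc3)C(=O)[C@H]21`, 98%

Compound 3 gives the highest number of the three. Against compound 1 the gap is small, a number 7 percentage points higher from compound 1 to compound 3 (within the scatter), so the two cannot be ordered; against compound 2 the step of a number 12 percentage points higher from compound 2 to compound 3 (beyond the scatter) goes beyond the scatter. Between compound 1 and compound 2 the step of a number 5 percentage points lower from compound 1 to compound 2 (within the scatter) is within the scatter.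

Compound 4, `COC(=O)[C@@H]1N=C(SC)[C@H]2C(=O)N(c3ccccc3)C(=O)[C@H]21`, is not yet measured. It differs from compound 3 by hydrogen in place of phenyl on a saturated chain carbon bound to a sulfur; cut one bond further out, the change reads benzylsulfanyl to methylsulfanyl. Among the measured compounds shown here, the steps that bear on it run the other way: adding phenyl in place of methyl gave a number 7 percentage points higher from compound 1 to compound 3 (within the scatter), adding phenyl in place of ethyl gave a number 12 percentage points higher from compound 2 to compound 3 (beyond the scatter). Removing the phenyl altogether, leaving a chain shorter than in compound 1 or compound 2, is therefore expected to lower the number by a modest amount, a number 11 percentage points lower from compound 3 to compound 4 (beyond the scatter), though the step may well fall within the scatter. Compound 4 is estimated at 87%, with a range from 75% to 97%.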

Compound 4, a percentage reported as inhibition, at one concentration (the size of the read-out at that concentration, not a potency): 93%
Compound 4: the middle estimate sits 6 percentage points below what was measured; the range from low to high includes it.
By their numbers in this assay, from the lowest: compounds 2, 1, 4 and 3 (each within the scatter of the next, the first and the last beyond it).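

In this assay, hydrogen in place of phenyl on the saturated chain carbon bound to the sulfur gives a step within the scatter (a number 5 percentage points lower from compound 3 to compound 4 (within the scatter)), so a high number at this position does not depend on the phenyl of benzylsulfanyl. Methylsulfanyl also cannot be separated from the two longer alkyl chains (a number 7 percentage points higher from compound 2 to compound 4 (within the scatter); a number 2 percentage points higher from compound 1 to compound 4 (within the scatter)), and these three compounds show no trend with chain length. No measurement here accounts for these numbers.

With each compound read at a single concentration and all numbers high, differences in potency among these sulfur substituents remain open. Also open, from the compounds shown here alone, is how an amine, a carboxylic acid or a chain longer than propyl would read on the sulfur.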